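The source may hold more compounds than are shown below. What is called first, only, known or untested is meant among the compounds shown, and "the series" means these compounds.

Measured in an in vitro ADME assay on microsomes (Homo sapiens) for metabolic stability; on this read-out lower numbers stand for a shorter-lived compound and higher numbers for a longer-lived compound:
- Compound 1 `CCc1nc(NC(CC)CC)cnc1-c1ccc(Cl)cc1Cl`: 0.467 h
- Compound 2 `CCOc1nc(-c2ccc(Cl)cc2Cl)c(CC)nc1NC(CC)CC`: 2 h
- Compound 3 `CCc1nc(NC(CC)CC)c(OC)nc1-c1ccc(Cl)cc1Cl`: 0.583 h

Compound 3 sits near the low end of these numbers: the data show a 1.2-fold higher number from compound 1 to compound 3 (0.10 log units; within the scatter) and a 3.4-fold lower number from compound 2 to compound 3 (0.54 log units; beyond the scatter). The unmeasured compound 4 `CCc1nc(NC(CC)CC)c(F)nc1-c1ccc(Cl)cc1Cl` differs from it by fluoro in place of methoxy on an aromatic carbon. Within the data shown here, no measured step brings in fluoro. The nearest guides are the two steps on that same carbon. With methoxy the data show a 1.2-fold higher number from compound 1 to compound 3 (0.10 log units; within the scatter), and with ethoxy they show a 4.3-fold higher number from compound 1 to compound 2 (0.63 log units; beyond the scatter). Only the ethoxy step lies beyond the scatter, so no change beyond the scatter is expected here. The expected step is a 1.1-fold lower number from compound 3 to compound 4 (0.03 log units; within the scatter). Compound 4 is estimated at 0.55 h, with an expected range of 0.27 h to 1.1 h.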

Compound 4, half-life: 1.22 h
Estimate against measurement, compound 4: 2.2-fold (0.35 log units) below, outside the stated range (above it).
By their numbers in this assay, from the lowest: compounds 1 and 3 (each within the scatter of the next); then compounds 4 and 2 (each within the scatter of the next).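

In this assay, among these compounds, fluoro on this aromatic carbon next to the ring nitrogen gives a 2.6-fold higher number from compound 1 to compound 4 (0.42 log units; beyond the scatter) and a 2.1-fold higher number from compound 3 to compound 4 (0.32 log units; beyond the scatter), so ethoxy is not the only group here that goes beyond the scatter from hydrogen. Against ethoxy, fluoro shows a 1.6-fold lower number from compound 2 to compound 4 (0.21 log units; within the scatter), and since methoxy stays within the scatter of hydrogen, the half-life does not rise steadily with group size. Nothing available explains this difference between fluoro and methoxy.

Going by these compounds, whether chloro, nitrile or an amine at this carbon would match fluoro or methoxy remains open. So does whether the fluoro step holds when the (pentan-3-yl)amino group changes.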